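Moving a Methyl Group on a Quinoline Thiosemicarbazone

A few compounds are considered here, and "the series" means these few. Any claim that something is new, unique, unknown or untested is made for them only; others in the source may bear on it.

Of the compounds shown here, two sharing one core have been tested in a functional assay on SGC-7901 cells (Homo sapiens) for antiproliferative activity, read by sulforhodamine B assay, with a stated time of 72 h; on this read-out lower numbers stand for stronger inhibition and higher numbers for weaker inhibition. Compound 1, `FC(F)(F)c1ccccc1NC(=S)N/N=C/c1ccc2ccccc2n1`, carries a trifluoromethyl-bearing phenyl ring on the amide-type nitrogen, and in this assay compound 1 gives 20700 nM. Compound 2, `Cc1ccc(NC(=S)N/N=C/c2ccc3ccccc3n2)cc1`, carries a 4-methylphenyl in the same position, and in this assay compound 2 gives 92900 nM. Among these two numbers compound 2 stands highest, so it is the weaker inhibitor of the pair; the gap to compound 1 is beyond the usual scatter of repeated measurements.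

Compound 3, `Cc1ccccc1NC(=S)N/N=C/c1ccc2ccccc2n1`, is not yet measured. Its difference from compound 2 is 2-methylphenyl in place of 4-methylphenyl on an amide-type nitrogen: the methyl group has changed its place on the phenyl ring, so the two compounds contain the same atoms joined differently. Among the compounds with values here, no directly measured pair of this kind is available to guide the expectation. With only compound 1 and compound 2 as anchors, a moderate step toward stronger inhibition is expected, a 2.1-fold lower number from compound 2 to compound 3 (0.31 log units; beyond the scatter), though a result within the scatter of compound 2 cannot be excluded. The estimate for compound 3 in this assay is therefore 45000 nM, within a range from 15000 nM to 140000 nM.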

Compound 3, half-maximal inhibitory concentration: > 100000 nM
Compound 3 was reported as a limit (the forecaster's own chance of this, stated with the estimate: 15%); middle value at least 2.2-fold (0.34 log units) away from the limit.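

In this assay compound 3 is reported only as a limit, not as a number: the limit of > 100000 nM in this assay, at which 1 of the 3 values shown sits.

Moving the methyl group from 4-methylphenyl to 2-methylphenyl on the amide-type nitrogen brought no gain in inhibition, but the step, an at least 1.0-fold higher number from compound 2 to compound 3 (0.03 log units; that floor lies within the scatter), gives only a floor, so the real size of the change remains unknown. Replacing trifluoromethyl with methyl gives a clearer result, an at least 4.8-fold higher number from compound 1 to compound 3 (0.68 log units; beyond the scatter), and this comparison is cleaner than the earlier one between compound 1 and compound 2, which differ in both the group and its place on the ring.

As far as these compounds go, how far compound 3 really sits from compound 2 stays open, as does whether the advantage of compound 1 belongs to trifluoromethyl alone or would extend to other groups. A chlorine atom, a methoxy group or an amine in that place on the phenyl ring, or a phenyl ring with no added group at all, would show how much the choice of group matters there.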